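The source may report more compounds than this note shows. Statements on the series, on what has been measured and on what is new or still open speak of the compounds shown alone.

Of the compounds shown here, three have been measured in an assay on isolated protein for displacement of a labelled ligand from 5-hydroxytryptamine receptor 6 (Homo sapiens), read by scintillation counting, with a stated time of 1 h; on this read-out higher numbers stand for weaker inhibition and lower numbers for stronger inhibition. Compound 1 `CN(C)c1cccc2c1ccn2S(=O)(=O)N1CCCCC1` gives 39100 nM. Compound 2 `O=S(=O)(c1ccccc1)n1ccc2ccc(-c3ccncc3)cc21` gives 38 nM. Compound 3 `CS(=O)(=O)n1ccc2ccc(-c3ccncc3)cc21` gives 4050 nM, which places compound 3 second highest of the three numbers, closer to compound 1 than to compound 2.

For the measured compounds named here, compound 3 shares its core with compound 2, and the one measured step between them is a 110-fold higher number from compound 2 to compound 3 (2.03 log units; beyond the scatter). Compound 1 differs from compound 3 in more than one place, so only its value can be set beside that of compound 3.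

Compound 4 `CCCCS(=O)(=O)n1ccc2ccc(-c3ccncc3)cc21` is not yet measured. It differs from compound 3 by propyl in place of hydrogen on a saturated chain carbon bound to a sulfonyl sulfur. The step from compound 2 to compound 3 bears directly on this change: shrinking the group on the sulfonyl sulfur from phenyl to methyl raised the number greatly. Growing that group from methyl to butyl moves part of the way back in size, though not toward a ring, so a moderate move in the opposite direction is expected, lowering the number beyond the scatter but falling well short of compound 2. The expected step is a 4.5-fold lower number from compound 3 to compound 4 (0.65 log units; beyond the scatter). Compound 4 is estimated to give 900 nM in this assay, within a range from 200 nM to 3500 nM.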

Compound 4, inhibition constant: 1150 nM
Compound 4: middle estimate off by 1.3-fold (0.11 log units), on the low side; the measured number falls inside the stated range.
By their numbers in this assay, from the lowest: compound 2; then compound 4; then compound 3; then compound 1.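

In this assay, the position on the sulfonyl sulfur proves sensitive to the length of a plain saturated chain, not only to the swap between a ring and a methyl: going from methyl to butyl gives a 3.5-fold lower number from compound 3 to compound 4 (0.55 log units; beyond the scatter). A chain adds only part of what the phenyl group provides, however, since replacing phenyl with butyl still leaves a 30-fold higher number from compound 2 to compound 4 (1.48 log units; beyond the scatter), a smaller loss than a 110-fold higher number from compound 2 to compound 3 (2.03 log units; beyond the scatter) but still a large one. So among the groups tested at this position, the butyl chain falls between methyl and phenyl, and compound 2 keeps the lowest number of the series. No measurement here explains why the butyl chain and the phenyl ring differ in this way.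

On these data alone, with only methyl and butyl to compare, it remains open whether a longer chain such as hexyl would lower the number further or reverse the gain, and whether a branched chain such as isobutyl would behave like butyl. As far as these compounds go, it is also open whether a benzyl group, or a butyl chain ending in an amine, could close the remaining gap to compound 2.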